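Methylsulfanyl for Trifluoromethyl: an Expected Step in Cytotoxicity

A few compounds are considered here, and "the series" means these few. Any claim that something is new, unique, unknown or untested is made for them only; others in the source may bear on it.

Measured compounds:
compound 1, `Cc1cc(NC(=O)Nc2ccc([N+](=O)[O-])c(C(F)(F)F)c2)c2ccccc2n1`: in an ADME assay on Raji cells (Homo sapiens) for cytotoxicity, with a stated time of 72 h (a lower number here means that less compound is needed, a higher number that more compound is needed for the effect), compound 1 gives > 25000 nM, a limit of the assay.
compound 2, `COc1ccc(NC(=O)Nc2cc(C)nc3ccccc23)cc1F`: in this assay compound 2 gives > 25000 nM, again a limit.
compound 3, `Cc1cc(NC(=O)Nc2ccccc2C(F)(F)F)c2ccccc2n1`: in this assay compound 3 gives > 25000 nM, also a limit.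

Going by the values given here, compound 3 therefore stands nowhere on a scale of numbers: its result is only the limit of this assay, and the two other compounds sit at the same limit, as the single piece of evidence states (the limit of > 25000 nM in this assay, at which 3 of the 3 values shown sit). Among the compounds with values here, no two measured compounds differ in only one place, so no measured step exists from which the effect of a single change could be read.

The unmeasured compound 4, `CSc1ccccc1NC(=O)Nc1cc(C)nc2ccccc12`, differs from compound 3 in one place: methylsulfanyl in place of trifluoromethyl on an aromatic carbon. With every measured compound at the limit of this assay, there is no number for compound 3 from which a step could start, and nothing in the data shows that this change moves a compound off the limit.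

The step from compound 3 to compound 4 is accordingly expected to be a step that the limit leaves unreadable from compound 3 to compound 4, that is, none beyond the scatter. Compound 4 is estimated at 50000 nM, within 15000 nM to 200000 nM, with a limit again the most likely outcome.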

Compound 4, half-maximal effective concentration: > 25000 nM
Compound 4 was reported as a limit; the forecaster's own chance of this, stated with the estimate: 85%; the middle value is on the limit's open side.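

In this assay compound 4 gives > 25000 nM as a limit of the assay. Going by these compounds alone, no step from compound 3 to compound 4 can be read, since both compounds sit at the same limit: the limit of > 25000 nM in this assay, at which 4 of the 4 values shown sit.

The compounds shown leave open what concentration any of them needs for the effect, and whether methylsulfanyl in place of trifluoromethyl changes it at all.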